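The source may report more compounds than this note shows. Statements on the series, on what has been measured and on what is new or still open speak of the compounds shown alone.

Compound 1 `O=C(O)c1ccccc1-c1ccc(CCc2ncc(CC3CCC3)[nH]2)cc1` gives 7.1 nM in an in vitro functional assay on cells for agonist activity at Bombesin receptor subtype-3 (Mus musculus), read by luminescence and calcium flux; a lower number here means that less compound is needed, a higher number that more compound is needed for the effect. Compound 2 `CCCCc1cnc(CCc2ccc(-c3ccccc3C(=O)O)cc2)[nH]1` gives 93 nM in this assay, and compound 3 `O=C(O)c1ccccc1-c1ccc(CCc2ncc(CCc3ccccc3)[nH]2)cc1` gives 174 nM. On these numbers compound 3 stands highest of the three: the step of a 25-fold higher number from compound 1 to compound 3 (1.39 log units; beyond the scatter) is large, while the gap from compound 2 to compound 3 is small, a 1.9-fold higher number from compound 2 to compound 3 (0.27 log units; within the scatter).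

Compound 4 `O=C(O)c1ccccc1-c1ccc(CCc2ncc(Cc3cccc(F)c3F)[nH]2)cc1` is the next compound. Its change from compound 3 is 2,3-difluorophenyl in place of benzyl on a saturated chain carbon bound to an aromatic carbon; cut one bond further out, the same difference reads phenethyl to 2,3-difluorobenzyl, so the ring is brought one carbon closer to the core and gains two fluorine atoms.

Within the data shown here, two measured steps bear on this. The step of a 25-fold higher number from compound 1 to compound 3 (1.39 log units; beyond the scatter) shows that the group on this saturated chain carbon matters greatly, with cyclobutyl far ahead of benzyl. The step of a 1.9-fold higher number from compound 2 to compound 3 (0.27 log units; within the scatter) shows that a ring two bonds out in place of ethyl changed little. Among the measured compounds shown here, no measured pair shows fluorine on that ring, and none shows a shorter link to it, so the direction is open. Compound 4 is expected to land near compound 3, perhaps somewhat lower, a 1.9-fold lower number from compound 3 to compound 4 (0.29 log units; within the scatter). The estimate for compound 4 is 90 nM, with a range from 25 nM to 300 nM.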

Compound 4, half-maximal effective concentration: 8 nM
The estimate for compound 4 lay 11-fold (1.05 log units) above the measured number; the measured number lies below the stated range.
By their numbers in this assay, from the lowest: compounds 1 and 4 (each within the scatter of the next); then compounds 2 and 3 (each within the scatter of the next).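

Before compound 4, the only aromatic ring at this place was the benzyl of compound 3, which stood within the scatter of the propyl of compound 2, so cyclobutyl looked like the one group that served well on this saturated chain carbon. The 2,3-difluorophenyl changes that reading: an aromatic ring can serve here too, as the two large steps show (a 22-fold lower number from compound 3 to compound 4 (1.34 log units; beyond the scatter)) and (a 12-fold lower number from compound 2 to compound 4 (1.07 log units; beyond the scatter)). Set against cyclobutyl, the new group cannot be told apart in this assay (a 1.1-fold higher number from compound 1 to compound 4 (0.05 log units; within the scatter)), although one is a saturated ring and the other an aromatic ring carrying two fluorine atoms, and nothing available explains why this change has so large an effect.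

The step joins two differences, a ring one carbon closer to the core and the two fluorine atoms, and the compounds shown do not separate them; a plain phenyl or a 2,3-difluorophenethyl on the same carbon would do so. Also open, from the compounds shown here alone, is whether a single fluorine atom, or a chlorine atom or methoxy group on that ring, would give a similar number.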